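Cyclopentane Nitrile Inhibitors of Cathepsin S: Amide Variation

This account rests on a few compounds, and the source may have more. Where it says the series, first, only, none or still open, it means among the compounds named here.

Compound 1 `N#CCNC(=O)[C@@H]1C[C@@H](S(=O)(=O)CC2CC2)C[C@H]1C(=O)N1CCOCC1`: 230 nM
Compound 2 `CN1CCN(C(=O)[C@@H]2C[C@H](S(=O)(=O)c3ccccc3)C[C@H]2C(=O)NC2(C#N)CC2)CC1`: 2 nM

Of the compounds shown here, two have been measured in an assay on isolated protein for inhibition of cathepsin S (Homo sapiens), read by fluorescence, with a stated time of 20 min; on this read-out lower numbers stand for stronger inhibition and higher numbers for weaker inhibition. Compound 1 gives 230 nM. Compound 2 gives 2 nM, the lower of the two numbers, and the gap to compound 1 lies well beyond the usual scatter. The two differ in several places at once, so no single cause can be read from their values.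

Compound 3 `N#CC1(NC(=O)[C@@H]2C[C@@H](S(=O)(=O)c3ccccc3)C[C@H]2C(=O)N2CCC2)CC1` has not been measured. It differs from compound 2 in one place: azetidin-1-yl in place of 4-methylpiperazin-1-yl on a carbonyl carbon. The rest of the molecule, including the sulfonyl group and the nitrile-bearing amide, is unchanged.

Going by the values given here, no measured pair shows what this change does. An expected step of a 2.0-fold higher number from compound 2 to compound 3 (0.30 log units; within the scatter) is small, at or only just beyond the scatter, in the direction of weaker inhibition. Compound 3 is therefore expected to give about 4 nM, within a range of 1 nM to 15 nM.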

Compound 3, half-maximal inhibitory concentration: 10 nM
The estimate for compound 3 lay 2.5-fold (0.40 log units) below the measured number, within the range that was stated.
By their numbers in this assay, from the lowest: compound 2; then compound 3; then compound 1.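

In this assay, going by these compounds alone, putting azetidin-1-yl in place of 4-methylpiperazin-1-yl on a carbonyl carbon gives a 5.0-fold higher number from compound 2 to compound 3 (0.70 log units; beyond the scatter) and so shows for the first time, in a single-place comparison, that the number responds to the group held here. The step is modest, so the change from 7 heavy atoms to 4 and from two ring nitrogens to one weakens inhibition only to a limited extent in this pair. No measurement at hand says why the number moves.

Ring size and the number of ring nitrogens change together here, so their separate contributions stay open. A piperidin-1-yl or pyrrolidin-1-yl group on the same carbonyl carbon, or an open-chain dimethylamino group, would be needed to tell them apart.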